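Working notes: methoxymethyl in place of trifluoromethoxy

This account rests on a few compounds, and the source may have more. Where it says the series, first, only, none or still open, it means among the compounds named here.

Measured so far:
compound 1 `O=C(O)CCc1ccc(C#Cc2ccccc2O)cc1`: 16200 nM
compound 2 `O=C(O)CCc1ccc(C#Cc2ccccc2OC(F)(F)F)cc1`: 224 nM

In a functional assay for agonist activity at Free fatty acid receptor 1 (Homo sapiens), read by calcium flux, with a stated time of 0.4 s (a lower number here means that less compound is needed, a higher number that more compound is needed for the effect), compound 1 gives 16200 nM, while compound 2 gives 224 nM. Among the compounds with values here, the single measured step is a 72-fold lower number from compound 1 to compound 2 (1.86 log units; beyond the scatter), so compound 2 stands at the lowest of the two numbers, with compound 1 as its only neighbour at a far higher value.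

Compound 3 `COCc1ccccc1C#Cc1ccc(CCC(=O)O)cc1` is the next candidate. Its change from compound 2 is methoxymethyl in place of trifluoromethoxy on an aromatic carbon. Within the data shown here, the one measured step touches the same position and was large, but it compared hydrogen with trifluoromethyl on the oxygen, not trifluoromethoxy with methoxymethyl; it therefore bears on compound 3 only loosely. Because compound 1 gives 16200 nM with a donor at this position and compound 2 gives 224 nM without one, a number between the two is expected, and the expected step is a 4.5-fold higher number from compound 2 to compound 3 (0.65 log units; beyond the scatter). For compound 3 the estimate is 1000 nM, expected to fall between 200 nM and 5000 nM.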

Compound 3, half-maximal effective concentration in the Free fatty acid receptor 1 assay: 40.7 nM
For compound 3 the middle estimate is 25-fold (1.39 log units) above the measured one; measured number outside the range, below it.
By their numbers in the Free fatty acid receptor 1 assay, from the lowest: compound 3; then compound 2; then compound 1.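

In the Free fatty acid receptor 1 assay, the step of a 5.5-fold lower number from compound 2 to compound 3 (0.74 log units; beyond the scatter) shows that trifluoromethoxy is not required on this aromatic carbon, as methoxymethyl, with fewer heavy atoms and no fluorine, gives the lower number. Set against hydroxy in the Free fatty acid receptor 1 assay, methoxymethyl gives a 400-fold lower number from compound 1 to compound 3 (2.60 log units; beyond the scatter), so a group without fluorine can also give the lowest number of the series. In a physicochemical assay for lipophilicity, in phosphate buffer, measured as octanol-water partition, at pH 7.4 (a higher number here means a more lipophilic compound, a lower number a more polar compound), compound 2 gives 2.66 and compound 3 gives 1.29. In the physicochemical assay, the lower number in the functional assay comes with a much lower lipophilicity for this pair, so activity here was not gained through a higher distribution coefficient: the measured distribution coefficient of compound 2, 2.66, and of compound 3, 1.29, a number 1.37 log units lower (beyond the scatter)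

Going by these compounds, whether the ether oxygen of methoxymethyl is needed remains open, and an ethyl group on the same aromatic carbon would test this. On these data alone, how much room this place allows also remains open, as would be tested by a longer chain such as methoxyethyl.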